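The compounds below may be only part of what the source reports. "The series", "measured", "known", "first", "only" and "open" are said of these compounds alone.

Measured so far in an ADME assay on WI-38 cells (Homo sapiens) for cytotoxicity, read by MTT assay, with a stated time of 72 h; on this read-out higher numbers stand for weaker inhibition and lower numbers for stronger inhibition:
compound 1 `O=C(CCc1cccc2c1B(O)OC2)Nc1ccccc1`: 30000 nM
compound 2 `CC(C)(C)OC(=O)NCc1ccc(NC(=O)CCc2cccc3c2B(O)OC3)cc1`: 4800 nM
compound 3 `O=C(CCc1cccc2c1B(O)OC2)Nc1ccccc1-c1ccccc1`: 77000 nM

Compound 1, at 30000 nM, holds the middle of the three numbers in this assay, lower than compound 3 and higher than compound 2. The next compound to be read is compound 4 `O=C(CCc1cccc2c1B(O)OC2)Nc1cccc(-c2ccc(F)cc2)c1`, which carries 4-fluorophenyl in place of hydrogen on an aromatic carbon.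

Going by the values given here, two measured steps bear on this change. The nearer in kind also brings in an aromatic ring, with phenyl in place of hydrogen on an aromatic carbon: a 2.6-fold higher number from compound 1 to compound 3 (0.41 log units; beyond the scatter). The other brings in ((tert-butoxycarbonyl)amino)methyl in place of hydrogen on an aromatic carbon: a 6.3-fold lower number from compound 1 to compound 2 (0.80 log units; beyond the scatter). Both steps are modest and they run in opposite directions, so no step beyond the scatter is expected, with a wide margin on either side.

The expected change is a 1.1-fold higher number from compound 1 to compound 4 (0.04 log units; within the scatter). For compound 4 the estimated value is 33000 nM, with an expected range of 9000 nM to 90000 nM.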

Compound 4, half-maximal inhibitory concentration: 4100 nM
For compound 4 the middle estimate is 8.0-fold (0.91 log units) above the measured one; measured number outside the range, below it.
By their numbers in this assay, from the lowest: compounds 4 and 2 (each within the scatter of the next); then compound 1; then compound 3.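

In this assay, 4-fluorophenyl on an aromatic carbon, meta to a large group, gives a 7.3-fold lower number from compound 1 to compound 4 (0.86 log units; beyond the scatter) and so runs against a 2.6-fold higher number from compound 1 to compound 3 (0.41 log units; beyond the scatter) in direction, which shows that bringing an aromatic ring onto this ring of the core does not by itself go with a higher number. Compound 4 and compound 2 stand within the scatter of each other, so a lower number here is not tied to ((tert-butoxycarbonyl)amino)methyl alone. No measurement at hand accounts for this step.

Open, as far as these compounds go, is how much of the difference between compound 3 and compound 4 belongs to the fluorine and how much to the place of the ring, as the two are not a single change apart. Also open, from the compounds shown here alone, is how this place responds to a group with no aromatic ring, such as an amine or a carboxylic acid.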